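Compound 4: methyl in place of cyclopentyloxy

A few compounds are considered here, and "the series" means these few. Any claim that something is new, unique, unknown or untested is made for them only; others in the source may bear on it.

In a functional assay on M21 cells (Homo sapiens) for inhibition, read by sulforhodamine B assay, with a stated time of 48 h (a higher number here means a weaker inhibitor of growth, a lower number a stronger inhibitor of growth), compound 2 `O=C(CCl)NC(=O)Nc1ccc(OC2CCCC2)cc1` gives 2900 nM and compound 3 `O=C(CCl)NC(=O)Nc1ccc(OCc2ccccc2)cc1` gives 5100 nM while compound 1 `c1ccc2cc(NC3=NCCO3)ccc2c1` gives 3500 nM on a different core. Compound 2 stands level with both of the others, since neither gap to it goes beyond the scatter.

The change from compound 2 to compound 4 `Cc1ccc(NC(=O)NC(=O)CCl)cc1` is methyl in place of cyclopentyloxy on an aromatic carbon on an aromatic carbon of a six-membered aromatic ring, para to a group of 8 heavy atoms.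

Going by the values given here, one measured step bears on this change. The step of a 1.8-fold higher number from compound 2 to compound 3 (0.25 log units; within the scatter) swaps only the group on the oxygen and stays within the scatter. Among the compounds with values here, no measured compound sharing the core of compound 2 lacks that oxygen, so removing the whole cyclopentyloxy group is untested here. Within the data shown here, with only that small step as a guide, no large shift is expected, and a slight lean towards a higher number is assumed.

In this assay the estimated change is a 1.7-fold higher number from compound 2 to compound 4 (0.24 log units; within the scatter) and it is expected to stay small. For compound 4 the estimate is 5000 nM with an expected range from 2000 nM to 13000 nM on present evidence.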

Compound 4, concentration for 50% growth inhibition: 4900 nM
Compound 4: middle estimate off by 1.0-fold (0.01 log units), on the high side; the measured number falls inside the stated range.
By their numbers in this assay, from the lowest: compounds 2, 1, 4 and 3 (each within the scatter of the next).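

The step to methyl reads a 1.7-fold higher number from compound 2 to compound 4 (0.23 log units; within the scatter) in this assay and so leaves compound 4 level with compound 2, even though the whole cyclopentyloxy group has gone, with its oxygen, its five-membered non-aromatic ring and its hydrogen-bond acceptor. The earlier step of a 1.8-fold higher number from compound 2 to compound 3 (0.25 log units; within the scatter) changed only the group on the oxygen, whereas this one shows that on the shared core, at this aromatic carbon, a group of 6 heavy atoms and a single carbon give numbers within the scatter of each other, so neither the oxygen nor the ring is required for a number of this size. Nothing at hand gives a cause for this flat reading.

On these data alone, whether an amine or a carboxylic acid on that aromatic carbon, or a longer chain on the oxygen, would carry the number beyond the scatter remains open. Both steps from compound 2 at this position stay within the scatter, so the compounds shown do not yet reveal any group here that shifts growth inhibition at all.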